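Sulfonyl for carbonyl on the ring nitrogen of compound 2

The compounds below may be only part of what the source reports. "The series", "measured", "known", "first", "only" and "open" are said of these compounds alone.

Compound 1 `CN(C)c1ccc(C2CC(c3ccc(-n4ccnc4)cc3)=NN2)cc1` and compound 2 `CN1CCN(c2ccc(C3=NN(C(=O)c4ccc(C(F)(F)F)cc4)C(c4ccc(N(C)C)cc4)C3)cc2)CC1` were both tested in a functional assay on NCI-H1975 cells (Homo sapiens) for inhibition, read by sulforhodamine B assay, tested at 10 uM; a higher number here means more inhibition at the concentration tested (going by the name of the read-out), a lower number less inhibition. Compound 1 gives 0.1%, while compound 2 gives 93.2%, the highest of the two numbers and a gap from compound 1 that lies beyond the scatter. Compound 3 `CN1CCN(c2ccc(C3=NN(S(=O)(=O)c4ccc(Br)cc4)C(c4ccc(N(C)C)cc4)C3)cc2)CC1` has not yet been measured; it differs from compound 2 by (4-bromophenyl)sulfonyl in place of (4-(trifluoromethyl)phenyl)carbonyl on an amine nitrogen in a ring. Because compound 2 reaches 93.2% with a (4-(trifluoromethyl)phenyl)carbonyl on an amine nitrogen in a ring, compound 3 is expected to keep most of that inhibition, so a small downward step a number 13.2 percentage points lower from compound 2 to compound 3 (beyond the scatter) is expected in this assay. Compound 3 is estimated at 80%, within 40% to 98%.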

Compound 3, a percentage reported as inhibition, at one concentration (the size of the read-out at that concentration, not a potency): 70.8%
Compound 3: the middle estimate sits 9.2 percentage points above what was measured; low and high end bracket the measured number.
By their numbers in this assay, from the lowest: compound 1; then compound 3; then compound 2.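

On the amine nitrogen in a ring, the (4-(trifluoromethyl)phenyl)carbonyl is not indispensable: in this assay the change to (4-bromophenyl)sulfonyl brings a number 22.4 percentage points lower from compound 2 to compound 3 (beyond the scatter), a modest but real loss, and compound 3 still gives 70.8%. Nothing at hand explains this loss. The sulfonyl and the bromine enter together, so the step cannot be divided between them. From the compounds shown here alone, a (4-bromophenyl)carbonyl on that nitrogen would separate the two, and whether an acetyl, without the aromatic ring, would keep any inhibition remains open.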